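The compounds below may be only part of what the source reports. "The series", "measured", "known", "first", "only" and "open" are said of these compounds alone.

Measured so far:
- compound 1, `C=Cc1cccc(C(=O)N2CCCC(C(=O)Nc3ccc(Cl)cc3)C2)c1`: 0%
- compound 2, `O=C(Nc1cccc([N+](=O)[O-])c1)C1CCCN(C(=O)c2cc(C(F)(F)F)cc(C(F)(F)F)c2)C1`: 9%
- compound 3, `O=C(Nc1ccc(Cl)cc1)C1CCCN(C(=O)c2ccc(-c3ccco3)cc2)C1`: 6%

In an ADME assay on PC-3 cells (Homo sapiens) for cytotoxicity, read by WST assay, tested at 100 uM (on this read-out lower numbers stand for less inhibition and higher numbers for more inhibition at the one concentration tested (going by the name of the read-out)), compound 1 gives 0%. Compound 3 gives 6% and compound 2 gives 9%; both of these numbers lie within the usual scatter of the number for compound 1, so the three compounds cannot be told apart on this read-out. All three show little inhibition of the cells.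

Compound 4, `O=C(Nc1ccc(Cl)cc1)C1CCCN(C(=O)c2cccc(-c3nccs3)c2)C1`, has not been measured in this assay. It differs from compound 1 in one place: 1,3-thiazol-2-yl in place of vinyl on an aromatic carbon. The measured compounds carry quite different groups on the same ring and still all sit near the bottom of the scale, so no step beyond the scatter is expected here. The estimated step is a number 5 percentage points higher from compound 1 to compound 4 (within the scatter), meaning compound 4 is expected to give about 5%, between 0% and 20%.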

Compound 4, a percentage reported as inhibition, at one concentration (the size of the read-out at that concentration, not a potency): 32%
For compound 4 the middle estimate is 27 percentage points below the measured one; the whole stated range lies below it.
By their numbers in this assay, from the lowest: compounds 1, 3 and 2 (each within the scatter of the next); then compound 4.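

Putting 1,3-thiazol-2-yl in place of vinyl on this aromatic carbon gives, in this assay, a number 32 percentage points higher from compound 1 to compound 4 (beyond the scatter). Within the data shown here, the low numbers of the earlier compounds therefore do not hold for every group here: one change at this place can lift the read-out beyond the scatter. No available evidence bears on why this happens.

As far as these compounds go, whether the step comes with any five-membered aromatic ring or needs the nitrogen and sulfur of this one stays open. A thiophene or a phenyl group at this place would help to separate these two readings.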